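A few compounds are considered here, and "the series" means these few. Any claim that something is new, unique, unknown or untested is made for them only; others in the source may bear on it.

In an ADME assay on MDBK cells (Bos taurus) for cytotoxicity, read by MTT assay, with a stated time of 96 h (a lower number here means that less compound is tolerated, a higher number that more compound is tolerated), compound 1 `CC(=O)c1ccc2[nH]c(-c3ccccc3)nc2c1` gives > 100000 nM, which is a limit. Compound 2 `CC(=O)c1ccc2[nH]c(-c3ccc(Cl)cc3)nc2c1` gives > 100000 nM, also a limit and not a number. Compound 3 `C/C(=N\NC(N)=O)c1ccc2[nH]c(-c3ccc(Cl)cc3)nc2c1` gives > 100000 nM, again a limit. The measured steps are a step that the two limits leave unreadable from compound 1 to compound 2 and a step that the two limits leave unreadable from compound 2 to compound 3. Within the data shown here, neither gives a size to carry forward, and the only evidence is the limit of > 100000 nM in this assay, at which 3 of the 3 values shown sit.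

Compound 4 `CC(=O)c1ccc2c(c1)nc(-c1ccc(Cl)cc1)n2C1CCCCC1` differs from compound 2 thus: cyclohexyl in place of hydrogen on an aromatic nitrogen. Neither measured step changes this ring nitrogen, so the data support no size or direction directly. Tentatively, an at least 1.4-fold lower number from compound 2 to compound 4 (0.15 log units; that floor lies within the scatter) is expected to be modest and towards less compound tolerated. this assay may again report only a limit. For compound 4 the estimate is 70000 nM, expected within 25000 nM to 100000 nM.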

Compound 4, half-maximal cytotoxic concentration: > 100000 nM
Compound 4 gave a limit, no number; the forecaster's own chance of this, stated with the estimate: 55%; at least 1.4-fold (0.15 log units) between middle value and limit.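

In this assay, among these compounds, compound 4 gives > 100000 nM, a limit, so no step from compound 2 to compound 4 can be read. The compounds shown leave open whether cyclohexyl in place of hydrogen on the aromatic nitrogen changes the tolerated concentration at all.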